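Methyl Added to the 4-Methoxyphenyl Group of Compound 1

The source may hold more compounds than are shown below. What is called first, only, known or untested is meant among the compounds shown, and "the series" means these compounds.

Measured so far:
compound 1 `COc1ccc(-c2cccc(=O)n2-c2cc(OC)c(OC)c(OC)c2)cc1` — < 10 nM
compound 2 `COc1ccc(-c2cccc(=O)n2-c2cc(OC)c(OC)c(OC)c2)cc1OC` — 545 nM
compound 3 `COc1cc(-n2c(-c3ccc(OC(F)(F)F)cc3)cccc2=O)cc(OC)c1OC` — 461 nM

In a functional assay on SK-OV-3 cells (Homo sapiens) for cytotoxicity, read by spectrophotometry, with a stated time of 72 h (on this read-out lower numbers stand for stronger inhibition and higher numbers for weaker inhibition), compound 1 gives < 10 nM. For compound 1 this reading is a limit of the assay, not a number (the limit of < 10 nM in this assay, at which 1 of the 3 values shown sits). Adding methoxy in place of hydrogen on an aromatic carbon gives an at least 54-fold higher number from compound 1 to compound 2 (1.73 log units; beyond the scatter), and trifluoromethyl in place of methyl on an oxygen on an aromatic ring gives an at least 46-fold higher number from compound 1 to compound 3 (1.66 log units; beyond the scatter). Compound 4 `COc1ccc(-c2cccc(=O)n2-c2cc(OC)c(OC)c(OC)c2)cc1C` differs from compound 1 by methyl in place of hydrogen on an aromatic carbon. The step bearing on it is an at least 54-fold higher number from compound 1 to compound 2 (1.73 log units; beyond the scatter), which places a group on the same aromatic carbon; a large step in the same direction is therefore expected, an at least 12-fold higher number from compound 1 to compound 4 (1.07 log units; beyond the scatter). Compound 4 is estimated at 120 nM, from 25 nM to 600 nM.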

Compound 4, half-maximal inhibitory concentration: 583 nM
Compound 4: the middle estimate sits 4.9-fold (0.69 log units) below what was measured; low and high end bracket the measured number.
By their numbers in this assay, from the lowest: compounds 3, 2 and 4 (each within the scatter of the next). At a limit, below all of these: compound 1.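

On the aromatic carbon ortho to a methoxy group, even methyl, a single carbon, gives an at least 58-fold higher number from compound 1 to compound 4 (1.76 log units; beyond the scatter). So the large step seen earlier with methoxy at this carbon is not confined to a group joined through oxygen. Methyl in place of methoxy gives a 1.1-fold higher number from compound 2 to compound 4 (0.03 log units; within the scatter), so compound 2 and compound 4 cannot be told apart here.

On these data alone, whether a fluorine, a chlorine or a hydroxyl at this carbon would behave the same stays open. The true size of the step also stays open, as compound 1 stands at a limit: the limit of < 10 nM in this assay, at which 1 of the 4 values shown sits.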